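The compounds below may be only part of what the source reports. "The series", "measured", "known", "first", "only" and "open" are said of these compounds alone.

Measured compounds:
Compound 1 `O=c1oc2ccc(Br)cc2c(=O)n1-c1ccc(Br)cc1F` gives 7200 nM in an ADME assay on RAW264.7 cells (Mus musculus) for cytotoxicity, read by MTT assay, with a stated time of 24 h; a lower number here means that less compound is tolerated, a higher number that more compound is tolerated.
Compound 2 `O=c1oc2ccc(Br)cc2c(=O)n1-c1ccc(F)cc1F` gives 16000 nM in this assay.
Compound 3 `O=c1oc2ccc(I)cc2c(=O)n1-c1ccc(F)cc1F` gives 15700 nM in this assay.

All three compounds share a core in which a two-ring system is joined to a separate six-membered aromatic ring, and they differ only in the halogen atoms attached to those rings. Compound 1 differs from compound 2 by bromo in place of fluoro on an aromatic carbon. This single exchange gave a 2.2-fold lower number from compound 2 to compound 1 (0.35 log units; beyond the scatter), a step just beyond the usual scatter of repeated measurements, so compound 1 is tolerated somewhat less well than compound 2.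

Compound 3 differs from compound 2 in the two-ring part of the core, by iodo in place of bromo on an aromatic carbon. Here the step was a 1.0-fold lower number from compound 2 to compound 3 (0.01 log units; within the scatter), so compound 2 and compound 3 cannot be told apart by this measurement.

Compound 4 `O=c1oc2ccc(I)cc2c(=O)n1-c1ccc(Br)cc1F` has not been measured in this assay. It differs from compound 3 by bromo in place of fluoro on an aromatic carbon. Among the compounds with values here, this is the same change as the one from compound 2 to compound 1, made at the same place, with the same surroundings, only on the core of compound 3 instead of the core of compound 2. Within the data shown here, since the core change itself left the number essentially unchanged, the earlier step is the only guide available. Compound 4 is therefore expected to show a step of a 2.2-fold lower number from compound 3 to compound 4 (0.34 log units; beyond the scatter), matching the earlier step, because compound 3 sits at 15700 nM and compound 1 fell below compound 2 by a 2.2-fold lower number from compound 2 to compound 1 (0.35 log units; beyond the scatter). Among the measured compounds shown here, the estimate for compound 4 is 7100 nM, expected to fall between 3600 nM and 14000 nM, with only one comparable step to rest on.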

Compound 4, half-maximal cytotoxic concentration: 8300 nM
Compound 4: middle estimate off by 1.2-fold (0.07 log units), on the low side, and the stated range covers the measured number.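

In this assay, bromo in place of fluoro on an aromatic carbon gives a 1.9-fold lower number from compound 3 to compound 4 (0.28 log units; within the scatter), and this step agrees with the one seen earlier for the same exchange on the other core: the same change on two cores in this assay, a 2.2-fold lower number (0.35 log units; beyond the scatter) from compound 2 to compound 1 and a 1.9-fold lower number (0.28 log units; within the scatter) from compound 3 to compound 4, 1.2-fold (0.07 log units) apart, within the scatter of two such steps. The exchange of iodo for bromo in the two-ring part, now read on the core that carries the second bromo, gives a 1.2-fold higher number from compound 1 to compound 4 (0.06 log units; within the scatter), and it also agrees with its earlier counterpart: the same change on two cores in this assay, a 1.0-fold lower number (0.01 log units; within the scatter) from compound 2 to compound 3 and a 1.2-fold higher number (0.06 log units; within the scatter) from compound 1 to compound 4, 1.2-fold (0.07 log units) apart, within the scatter of two such steps. Together, these two comparisons show that each halogen exchange behaves alike on the two cores tested, but each rests on only one pair of steps, and one bromo step lies beyond the scatter while the other lies within it, so they neither fix the size of the bromo step closely nor show that it would carry over to any further core.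

Every substituent shown at these two places is a halogen, so it remains open whether the same agreement would hold for an amine, a carboxylic acid or a methoxy group there. Also open, from the compounds shown here alone, is how a chloro group would compare at either place, and whether the bromo step would hold with fluoro on the two-ring part.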